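The source may hold more compounds than are shown below. What is called first, only, known or untested is meant among the compounds shown, and "the series" means these compounds.

Measured so far in a physicochemical assay for lipophilicity, using the shake flask method, in phosphate buffer, measured as octanol-water partition, with a stated time of 30 min, at pH 7.4; on this read-out lower numbers stand for lower lipophilicity and higher numbers for higher lipophilicity:
compound 1, `O=C1CCCN1c1cnc(NCc2c(F)ccc3c2CCO3)n2cnnc12`: 1.3
compound 2, `O=C(Nc1cnc(NCc2c(F)ccc3c2CCO3)n2cnnc12)c1ccccc1`: 3
compound 3, `CN(c1ccccc1)c1cnc(NCc2c(F)ccc3c2CCO3)n2cnnc12`: 3.6

Compound 3 stands highest of the three; the nearest number is that of compound 2, and the gap to compound 1 is the widest in the set. The measured steps run a number 1.70 log units higher from compound 1 to compound 2 (beyond the scatter) and a number 2.30 log units higher from compound 1 to compound 3 (beyond the scatter), both large, and a number 0.60 log units higher from compound 2 to compound 3 (beyond the scatter), modest; all three exchange the whole group on the aromatic carbon.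

Compound 4, `CN(c1ncco1)c1cnc(NCc2c(F)ccc3c2CCO3)n2cnnc12`, is not yet measured. It differs from compound 3 in the phenyl hanging on the methylated nitrogen: 1,3-oxazol-2-yl in place of phenyl on a nitrogen on an aromatic ring

For the measured compounds named here, no measured step exchanges an aryl group on that nitrogen, so the step is without a direct precedent here; the steps already seen only show that exchanges at this position move this assay well beyond the scatter. The entering ring carries two hydrogen-bond acceptors where phenyl carried none, and a downward step is therefore expected, estimated at a number 1.30 log units lower from compound 3 to compound 4 (beyond the scatter). Compound 4 is estimated at 2.3, with a range from 1.7 to 2.9.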

Compound 4, distribution coefficient: 2.1
Compound 4: the middle estimate sits 0.20 log units above what was measured; measured number inside the range.
By their numbers in this assay, from the lowest: compound 1; then compound 4; then compound 2; then compound 3.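

In this assay, the aryl group on the methylated nitrogen proves a strong lever by itself: 1,3-oxazol-2-yl in place of phenyl gives a number 1.50 log units lower from compound 3 to compound 4 (beyond the scatter) with the rest of the molecule unchanged. The methyl(1,3-oxazol-2-yl)amino group lands among the other groups on the aromatic carbon, with a number 0.90 log units lower from compound 2 to compound 4 (beyond the scatter) against benzamido and a number 0.80 log units higher from compound 1 to compound 4 (beyond the scatter) against 2-oxopyrrolidin-1-yl, so the methylated nitrogen alone does not set the high end of the series. Nothing available accounts for the size of the phenyl to 1,3-oxazol-2-yl step.

The step changes ring size and hetero atoms together, and pyridin-2-yl on the same nitrogen would separate the two. Also open, as far as these compounds go, is how much the methyl group contributes, which the secondary amine carrying 1,3-oxazol-2-yl would show.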